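Arylpiperazine swap on the saccharin-type sultam core

This account rests on a few compounds, and the source may have more. Where it says the series, first, only, none or still open, it means among the compounds named here.

Two compounds of the series have numbers in an assay on HEK293 cells for displacement of a labelled ligand from 5-hydroxytryptamine receptor 6 (Homo sapiens); on this read-out higher numbers stand for weaker inhibition and lower numbers for stronger inhibition. Compound 1 `O=C1c2ccccc2S(=O)(=O)N1CCCCCN1CCN(c2ncccn2)CC1` gives 7100 nM. Compound 2 `O=C1c2ccccc2S(=O)(=O)N1CCCCCN1CCN(c2cccc(Cl)c2Cl)CC1` gives 197 nM. Compound 2 therefore has the lower of the two numbers; the gap between them is a 36-fold lower number from compound 1 to compound 2 (1.56 log units; beyond the scatter), which came with 2,3-dichlorophenyl in place of pyrimidin-2-yl on the amine nitrogen in the ring.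

Compound 3 `O=C1c2ccccc2S(=O)(=O)N1CCCCCN1CCN(c2cccc3ccccc23)CC1` is not yet measured. It differs from compound 2 in one place: naphthalen-1-yl in place of 2,3-dichlorophenyl on an amine nitrogen in a ring.

For the measured compounds named here, the only step measured so far, from compound 1 to compound 2, exchanged a heteroaryl ring for a carbon-only aromatic ring and was large. Going by the values given here, the step to compound 3 keeps a carbon-only aromatic system on the same nitrogen and enlarges it to two fused rings; no measured pair in this assay shows what such an enlargement does. Compound 3 is therefore expected to stay near compound 2, with at most a modest change in this assay, estimated as a 1.6-fold lower number from compound 2 to compound 3 (0.22 log units; within the scatter). For compound 3 the expected value is 120 nM, within a range from 30 nM to 500 nM.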

Compound 3, inhibition constant: 101 nM
Estimate against measurement, compound 3: 1.2-fold (0.07 log units) above, within the range that was stated.
By their numbers in this assay, from the lowest: compounds 3 and 2 (each within the scatter of the next); then compound 1.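

In this assay, replacing 2,3-dichlorophenyl with naphthalen-1-yl on the amine nitrogen in the ring gives a 2.0-fold lower number from compound 2 to compound 3 (0.29 log units; within the scatter), so this position takes 2 six-membered aromatic rings of carbon only in place of one such ring bearing 2 chlorine without a change that can be read. Against the pyrimidin-2-yl of compound 1, the large step now appears with a second carbon-only aromatic group, a 70-fold lower number from compound 1 to compound 3 (1.85 log units; beyond the scatter), and both carbon-only groups shown stand well apart from that heteroaryl group, with none of the three compounds going against this. No measured evidence bears on why the two carbon-only groups read alike or why both differ so far from pyrimidin-2-yl.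

The compounds shown leave open whether an unsubstituted phenyl, a phenyl with a single chlorine or naphthalen-2-yl on the same nitrogen would stay at this level. They also leave open how a shorter or longer chain between the shared core and the six-membered ring with 2 nitrogen would act together with naphthalen-1-yl.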